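Aryl amino variation: 4-methoxyphenyl to 4-nitrophenyl

A few compounds are considered here, and "the series" means these few. Any claim that something is new, unique, unknown or untested is made for them only; others in the source may bear on it.

- compound 1 `COc1ccc(S(=O)(=O)N2CCc3cccc(Nc4ccc(O)cc4)c32)cc1` gives 493 nM
- compound 2 `COc1ccc(Nc2cccc3c2N(S(=O)(=O)c2ccc(OC)cc2)CC3)cc1` gives 487 nM
- compound 3 `COc1ccc(S(=O)(=O)N2CCc3cccc(Nc4ccc(F)c(F)c4)c32)cc1` gives 726 nM

In a functional assay on MKN-45 cells (Homo sapiens) for antiproliferative activity (a lower number here means a stronger inhibitor, a higher number a weaker inhibitor), compound 2 gives 487 nM and lies within the scatter of both other compounds, so the three values do not separate. Compound 4 `COc1ccc(S(=O)(=O)N2CCc3cccc(Nc4ccc([N+](=O)[O-])cc4)c32)cc1` alters compound 2 in one place nitro in place of methoxy on an aromatic carbon with nitro in place of methoxy on an aromatic carbon, para to a large group. For the measured compounds named here, the same aryl group has been varied in all three measured compounds, and the record there reads a 1.0-fold lower number from compound 1 to compound 2 (0.01 log units; within the scatter) and a 1.5-fold higher number from compound 1 to compound 3 (0.17 log units; within the scatter) and also a 1.5-fold higher number from compound 2 to compound 3 (0.17 log units; within the scatter) with no step leaving the scatter. Going by the values given here, no measured compound carries a nitro group, so this reading rests on three compounds and on other substituents only. No shift beyond the scatter is expected, and the estimated step is a 1.2-fold higher number from compound 2 to compound 4 (0.09 log units; within the scatter) without a firm direction. The estimate for compound 4 in this assay is an expected 600 nM with a range from 250 nM to 1500 nM for this untested group.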

Compound 4, half-maximal inhibitory concentration: 107 nM
Estimate against measurement, compound 4: 5.6-fold (0.75 log units) above; the whole stated range lies above it.
By their numbers in this assay, from the lowest: compound 4; then compounds 2, 1 and 3 (each within the scatter of the next).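

In this assay, for the compounds shown here, nitro is the first change on this aryl group to leave the scatter, with a 4.6-fold lower number from compound 2 to compound 4 (0.66 log units; beyond the scatter), a 4.6-fold lower number from compound 1 to compound 4 (0.66 log units; beyond the scatter) and a 6.8-fold lower number from compound 3 to compound 4 (0.83 log units; beyond the scatter), which makes compound 4 the most potent of the four. The position therefore responds to its substituent, even though the hydroxy, methoxy and 3,4-difluoro compounds do not separate from one another. Nothing available accounts for this gain.

As far as these compounds go, only compound 4 carries the gain, so it remains open whether it is specific to nitro or would also appear with a nitrile or a trifluoromethyl group on the same aromatic carbon. Also open, from the compounds shown here alone, is what an amine or a carboxylic acid would give there, and whether the gain holds on changes to the shared core.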